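A few compounds are considered here, and "the series" means these few. Any claim that something is new, unique, unknown or untested is made for them only; others in the source may bear on it.

Three compounds share one core and differ only in the group on an amine nitrogen in a ring. In a functional assay on KB cells (Homo sapiens) for cytotoxicity, read by MTT assay, with a stated time of 3 days (a higher number here means a weaker inhibitor, a lower number a stronger inhibitor), compound 1 `N#Cc1c(-c2ccccc2)nc(SCc2nc3ccccc3[nH]2)nc1N1CCNCC1` gives 2.87 nM, compound 2 `CN1CCN(c2nc(SCc3nc4ccccc4[nH]3)nc(-c3ccccc3)c2C#N)CC1` gives 2.7 nM, and compound 3 `Cc1ccc(S(=O)(=O)N2CCN(c3nc(SCc4nc5ccccc5[nH]4)nc(-c4ccccc4)c3C#N)CC2)cc1`, which carries a (4-methylphenyl)sulfonyl group there, gives 3.28 nM. These numbers lie within the usual scatter of one another, so compound 3 stands level with the other two.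

Still unmeasured is compound 4 `N#Cc1c(-c2ccccc2)nc(SCc2nc3ccccc3[nH]2)nc1N1CCN(S(=O)(=O)c2ccccc2[N+](=O)[O-])CC1`, which keeps the sulfonyl sulfur but changes the group on it: 2-nitrophenyl in place of 4-methylphenyl on a sulfonyl sulfur. In words, 2-nitrophenyl sits in place of 4-methylphenyl on a sulfonyl sulfur.

Among the compounds with values here, the steps that bear on this change are those at the ring nitrogen: a 1.1-fold higher number from compound 1 to compound 3 (0.06 log units; within the scatter), a 1.2-fold higher number from compound 2 to compound 3 (0.08 log units; within the scatter) and a 1.1-fold lower number from compound 1 to compound 2 (0.03 log units; within the scatter). All three lie within the scatter. None of them swaps the group on the sulfonyl sulfur, so this evidence is only indirect. Even so, with no measured step beyond the scatter, none is expected here in this assay, in either direction. The estimated step is a 1.0-fold lower number from compound 3 to compound 4 (0.01 log units; within the scatter). For compound 4 the expected value is 3.2 nM, with an estimated range from 1.4 nM to 7.5 nM.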

Compound 4, half-maximal inhibitory concentration: 4.44 nM
For compound 4 the middle estimate is 1.4-fold (0.14 log units) below the measured one, and the stated range covers the measured number.
By their numbers in this assay, from the lowest: compounds 2, 1, 3 and 4 (each within the scatter of the next).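

Until now, only the whole group on the ring nitrogen had been exchanged, whereas compound 4 changes the group on the sulfonyl sulfur itself. In this assay, putting 2-nitrophenyl in place of 4-methylphenyl gives a step that stays within the scatter (a 1.4-fold higher number from compound 3 to compound 4 (0.13 log units; within the scatter)), so the two aryl groups on the sulfonyl sulfur cannot be told apart here. The wider comparisons with the two compounds that have no sulfonyl group also stay within the scatter (a 1.6-fold higher number from compound 2 to compound 4 (0.22 log units; within the scatter) and a 1.5-fold higher number from compound 1 to compound 4 (0.19 log units; within the scatter)), so hydrogen, methyl, (4-methylphenyl)sulfonyl and (2-nitrophenyl)sulfonyl on this nitrogen all stand level in this cell assay. No measurement among these data offers an account of this flat result.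

The compounds shown leave open whether any group on this nitrogen can move the number beyond the scatter, for example an amine or a carboxylic acid on the phenyl ring, or a simple methyl in place of the phenyl on the sulfonyl sulfur. They also leave open whether an acetyl group, which would put a carbonyl on the nitrogen in place of the sulfonyl group, would stand level with these four.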